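Swapping one aromatic substituent across two related cores

The source may hold more compounds than are shown below. What is called first, only, known or untested is meant among the compounds shown, and "the series" means these compounds.

Compound 1 `Cc1cc(=O)n(-c2cccc(F)c2)nc1C(=O)Nc1ccc(Oc2ncnc3[nH]ccc23)c(F)c1` and compound 2 `Cc1cc(=O)n(-c2ccc(Br)cc2F)nc1C(=O)Nc1ccc(Oc2ncnc3[nH]ccc23)c(F)c1` share one core, while compound 3 `Cc1cc(=O)n(-c2ccc(Br)cc2F)nc1C(=O)Nc1ccc(Oc2ncnc3c2ccn3C)c(F)c1` and compound 4 `Cc1cc(=O)n(-c2cccc(F)c2)nc1C(=O)Nc1ccc(Oc2ncnc3c2ccn3C)c(F)c1` share another; the two cores differ by methyl in place of hydrogen on an aromatic nitrogen. In a functional assay on MCF7 cells (Homo sapiens) for cytotoxicity, read by MTT assay, with a stated time of 72 h (a lower number here means a stronger inhibitor, a higher number a weaker inhibitor), compound 1 gives 32000 nM and compound 2 gives 26600 nM. For compound 3 this assay reports only a limit, > 60000 nM, which is the limit of > 60000 nM in this assay, at which 1 of the 3 values shown sits. The step of a 1.2-fold higher number from compound 2 to compound 1 (0.08 log units; within the scatter) comes from 3-fluorophenyl in place of 4-bromo-2-fluorophenyl on an aromatic nitrogen, whereas an at least 2.2-fold higher number from compound 2 to compound 3 (0.35 log units; beyond the scatter) comes from the core change. Compound 4 differs from compound 3 by 3-fluorophenyl in place of 4-bromo-2-fluorophenyl on an aromatic nitrogen, the same change as that from compound 2 to compound 1. Because a 1.2-fold higher number from compound 2 to compound 1 (0.08 log units; within the scatter) lies within the scatter, the expected step is a step that the limit leaves unreadable from compound 3 to compound 4. Compound 4 is therefore expected to give roughly 75000 nM in this assay, most probably again only as a limit, within an estimated range from 40000 nM to 160000 nM.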

Compound 4, half-maximal inhibitory concentration: > 60000 nM
Compound 4: a limit, no number; the forecaster's own chance of this, stated with the estimate: 75%; the middle value lies beyond the limit too.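

In this assay, methyl in place of hydrogen on an aromatic nitrogen gives an at least 1.8-fold higher number from compound 1 to compound 4 (0.27 log units; that floor lies within the scatter), while the step between compound 3 and compound 4 cannot be read. Set side by side, the methyl change gives no lower number in either pair, but the sizes of its two steps cannot be compared: the same change on two cores in this assay, an at least 2.2-fold higher number (0.35 log units; beyond the scatter) from compound 2 to compound 3 and an at least 1.8-fold higher number (0.27 log units; that floor lies within the scatter) from compound 1 to compound 4; the limit leaves it open whether they differ. On these data alone, what carries over between the two aryl groups is thus only this direction, and its true size on either remains unknown: the limit of > 60000 nM in this assay, at which 2 of the 4 values shown sit.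

The compounds shown leave open how a longer chain such as ethyl or propyl would behave in place of that methyl. They also leave open what an amine or a carboxylic acid on the aryl group would do to the number in this assay.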